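A few compounds are considered here, and "the series" means these few. Any claim that something is new, unique, unknown or untested is made for them only; others in the source may bear on it.

Compound 1 `Fc1ccc(C2=NN(C3=NC(c4ccccc4)CS3)C(c3cccc4ccccc34)C2)cc1`: 12400 nM
Compound 2 `O=C1CSC(N2N=C(c3ccc(Cl)cc3)CC2c2cccc3ccccc23)=N1`: 8840 nM
Compound 3 `O=C1CSC(N2N=C(c3ccc(Br)cc3)CC2c2ccc3ccccc3c2)=N1`: 4220 nM

All three were tested in a functional assay on HeLa cells (Homo sapiens) for inhibition, read by CCK-8 assay, with a stated time of 48 h; a higher number here means a weaker inhibitor, a lower number a stronger inhibitor. Compound 2, at 8840 nM, lies within the scatter of compound 1, at 12400 nM, while compound 3, at 4220 nM, gives a lower number beyond the scatter. Compound 4 `O=C1CSC(N2N=C(c3ccc(F)cc3)CC2c2cccc3ccccc23)=N1` has not yet been measured. It departs from compound 2 in one place: fluoro in place of chloro on an aromatic carbon. This is fluoro in place of chloro on an aromatic carbon. Among the compounds with values here, no measured pair shows this change on its own, so no step beyond the scatter is expected in this assay, in either direction. The estimated step of a 1.1-fold higher number from compound 2 to compound 4 (0.03 log units; within the scatter) is therefore small. For compound 4 the expected value is 9500 nM, with an estimated range from 4000 nM to 22000 nM.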

Compound 4, half-maximal inhibitory concentration: 11300 nM
For compound 4 the middle estimate is 1.2-fold (0.08 log units) below the measured one; the measured number falls inside the stated range.
By their numbers in this assay, from the lowest: compound 3; then compounds 2, 4 and 1 (each within the scatter of the next).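

In this assay, within the data shown here, the change from 4-chlorophenyl to 4-fluorophenyl gives a 1.3-fold higher number from compound 2 to compound 4 (0.11 log units; within the scatter), the first reading of a single change at this position, and it shows no separation between these two halogens. The exchange of the group on the amine nitrogen in a ring gives a 1.1-fold lower number from compound 1 to compound 4 (0.04 log units; within the scatter), so those two groups are not told apart here either. Nothing measured bears on why these steps are this small. Going by these compounds, whether an amine or a methoxy group on that aromatic carbon would give a step beyond the scatter remains open. Compound 3 differs from the others in more than one place, so its number cannot be tied to a single change.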